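The source may report more compounds than this note shows. Statements on the series, on what has been measured and on what is new or still open speak of the compounds shown alone.

Compound 2 `NCc1nc2ccccc2c(-c2ccccc2)c1C(=O)NCc1cc(C(F)(F)F)cc(C(F)(F)F)c1` gives the lower of the two numbers recorded in an in vitro assay on UC11MG cells for binding affinity to Substance-P receptor (Homo sapiens), read by radioligand binding (a higher number here means a weaker inhibitor, a lower number a stronger inhibitor), namely 0.0017 nM; compound 1 `Cc1nc2ccccc2c(-c2ccccc2)c1C(=O)N(C)Cc1cc(C(F)(F)F)cc(C(F)(F)F)c1` gives 3.1 nM in this assay, and the two structures differ in more than one place, so their values are compared without assigning the gap to any single change. Compound 3 `CN(Cc1cc(C(F)(F)F)cc(C(F)(F)F)c1)C(=O)c1c(CN)nc2ccccc2c1-c1ccccc1` has not been measured in this assay. It differs from compound 2 by methyl in place of hydrogen on an amide-type nitrogen. Among the measured compounds shown here, with no measured step isolating this change, the expected shift from compound 2 to compound 3 is uncertain in size and is estimated at an 18-fold higher number from compound 2 to compound 3 (1.25 log units; beyond the scatter), with a weaker value judged more likely than a stronger one. Compound 3 is therefore expected to give about 0.03 nM in this assay, with a range from 0.002 nM to 0.5 nM.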

Compound 3, half-maximal inhibitory concentration: 9 nM
Compound 3: middle estimate off by 300-fold (2.48 log units), on the low side; the measured number lies above the stated range.
By their numbers in this assay, from the lowest: compound 2; then compound 1; then compound 3.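

The largest change yet isolated sits on the amide-type nitrogen: methyl in place of hydrogen gives a 5300-fold higher number from compound 2 to compound 3 (3.72 log units; beyond the scatter) in this assay and is a large step. With that methyl present, amino in place of hydrogen on the saturated chain carbon gives no gain, only a modest 2.9-fold higher number from compound 1 to compound 3 (0.46 log units; beyond the scatter) in the weaker direction. No measurement shown here accounts for either step.

Still open, as far as these compounds go, is whether an ethyl group or a longer chain on that nitrogen would behave like methyl. Also open, from the compounds shown here alone, is how a hydroxyl group would compare with the amino group when the amide hydrogen is kept.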